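This account rests on a few compounds, and the source may have more. Where it says the series, first, only, none or still open, it means among the compounds named here.

Compound 1 `Cc1ccc(S(=O)(=O)c2nc3ccccc3nc2Nc2ccc(Cl)cc2)cc1` gives 2050 nM in a functional assay on HCT-116 cells (Homo sapiens) for cytotoxicity, read by MTT assay, with a stated time of 72 h; on this read-out higher numbers stand for weaker inhibition and lower numbers for stronger inhibition.
Compound 2 `Cc1ccc(S(=O)(=O)c2nc3ccccc3nc2Nc2ccc(C(F)(F)F)cc2)cc1` gives 950 nM.
Compound 3 `COc1ccc(S(=O)(=O)c2nc3ccccc3nc2Nc2ccc(Cl)cc2)cc1` gives 26500 nM.

Compound 1 and compound 2 differ by trifluoromethyl in place of chloro on an aromatic carbon, and that change gave a 2.2-fold lower number from compound 1 to compound 2 (0.33 log units; beyond the scatter). Compound 3 carries a different core, set apart from compound 1 by methoxy in place of methyl on an aromatic carbon, a change that gave a 13-fold higher number from compound 1 to compound 3 (1.11 log units; beyond the scatter). Compound 4 `COc1ccc(S(=O)(=O)c2nc3ccccc3nc2Nc2ccc(C(F)(F)F)cc2)cc1` is not yet measured; it differs from compound 3 by trifluoromethyl in place of chloro on an aromatic carbon, the same change as between compound 1 and compound 2, on the same kind of place. Because the earlier step read a 2.2-fold lower number from compound 1 to compound 2 (0.33 log units; beyond the scatter), a step of about the same size is expected here, a 2.2-fold lower number from compound 3 to compound 4 (0.34 log units; beyond the scatter), though it rests on one pair. Compound 4 is therefore estimated at 12000 nM, between 5000 nM and 30000 nM.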

Compound 4, half-maximal inhibitory concentration: 110 nM
The estimate for compound 4 lay 110-fold (2.04 log units) above the measured number; measured number below the stated range.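

In this assay, trifluoromethyl in place of chloro, carried to the methoxy-bearing core, gave a 240-fold lower number from compound 3 to compound 4 (2.38 log units; beyond the scatter), so the size of this step did not transfer from one core to the other: the same change on two cores in this assay, a 2.2-fold lower number (0.33 log units; beyond the scatter) from compound 1 to compound 2 and a 240-fold lower number (2.38 log units; beyond the scatter) from compound 3 to compound 4, 110-fold (2.05 log units) apart, beyond the scatter of two such steps
Methoxy in place of methyl changed direction with the other group present, giving an 8.6-fold lower number from compound 2 to compound 4 (0.94 log units; beyond the scatter): the same change on two cores in this assay, a 13-fold higher number (1.11 log units; beyond the scatter) from compound 1 to compound 3 and an 8.6-fold lower number (0.94 log units; beyond the scatter) from compound 2 to compound 4, 110-fold (2.05 log units) apart, beyond the scatter of two such steps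
The two changes therefore do not act independently in these four compounds, but this square alone does not show why, nor that the same holds for any other compound in the series.

As far as these compounds go, it remains open whether an ethoxy or a dimethylamino group in place of methoxy would behave the same way. The same question stands for a nitrile in place of trifluoromethyl.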